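Aryl thiourea series: cytotoxicity working notes

This account rests on a few compounds, and the source may have more. Where it says the series, first, only, none or still open, it means among the compounds named here.

Measured so far:
compound 1 `CC(CCOc1ccccc1)CCOc1cccc(NC(N)=S)c1`: > 50000 nM
compound 2 `NC(=S)Nc1cccc(OCCCCCOc2ccc(C(=O)O)cc2)c1`: > 50000 nM

Both readings come from an ADME assay on Ava5 cells (Homo sapiens) for cytotoxicity; on this read-out lower numbers stand for higher toxicity in this test and higher numbers for lower toxicity in this test. For compound 1 the value > 50000 nM is a limit of this assay and not a number. For compound 2 the value > 50000 nM is likewise a limit of this assay and not a number. Compound 2 thus stands at the limit of > 50000 nM in this assay, at which 2 of the 2 values shown sit. No number separates it from compound 1, and no order between the two can be stated.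

Compound 3 `NC(=S)Nc1cccc(OCCCCCOc2ccc(-c3cccs3)cc2)c1` is not yet measured in this assay. It differs from compound 2 by thiophen-2-yl in place of carboxy on an aromatic carbon. Among the compounds with values here, no step between measured compounds is known, so there is no gradient from which a change could be derived. Both measured compounds sit at the limit. Compound 3 is expected to remain in the same region. The step from compound 2 to compound 3 is estimated as a number no higher from compound 2 to compound 3 (the limit leaves the size open), which means none beyond the scatter. Compound 3 is estimated at 50000 nM, with a range from 15000 nM to 100000 nM, and a limit rather than a number is considered the likelier outcome.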

Compound 3, half-maximal cytotoxic concentration: > 50000 nM
Compound 3: only a limit was reported (the forecaster's own chance of this, stated with the estimate: 70%); the middle value lies on the limit itself.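

In this assay compound 3 gives > 50000 nM, which is a limit and not a number. No step can be read between compound 2 and compound 3, as both stand at a limit: the limit of > 50000 nM in this assay, at which 3 of the 3 values shown sit. The compounds shown leave open what actual cytotoxic concentration any of the three has in this assay.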